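The source may hold more compounds than are shown below. What is called first, only, known or untested is meant among the compounds shown, and "the series" means these compounds.

Working notes on the series, read in a functional assay on A549 cells (Homo sapiens) for antiproliferative activity, read by luminescence and CellTiter-Glo, with a stated time of 48 h; a higher number here means a weaker inhibitor, a lower number a stronger inhibitor. Compound 1 (`COc1ccc(/C=C/[C@H]2CC=CC(=O)O2)cc1`) gives only a limit, > 100000 nM. Compound 2 (`C[C@@H](Cc1ccccc1)[C@H]1CCCC(=O)O1`) also gives only a limit, > 100000 nM. Compound 3 (`COc1ccc(/C=C/[C@@H]2CC=CC(=O)O2)cc1`) gives a limit as well, > 100000 nM, so no numerical potency can be assigned to it. The whole set therefore stands at the limit of > 100000 nM in this assay, at which 3 of the 3 values shown sit.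

Compound 4 (`O=C1C=CC[C@@H](/C=C/c2ccc(F)cc2)O1`) has fluoro in place of methoxy on an aromatic carbon, para to a group of 9 heavy atoms: fluoro in place of methoxy on an aromatic carbon. Within the data shown here, the only measured step touching compound 3 is a step that the two limits leave unreadable from compound 1 to compound 3. It reflects the fact that compounds 1 and 3 differ only in the configuration as drawn and leaves the methoxy group in place, so it gives no size for this exchange. Among the measured compounds shown here, no measured step covers a change at this aromatic carbon.

With no readable step to carry over, no defined shift is expected in this assay. Since compound 3 sits at a limit of > 100000 nM, any readable result for compound 4 would have to fall on the stronger side, but the most likely outcome is another limit. The expected step is a number no higher from compound 3 to compound 4 (the limit leaves the size open). Compound 4 is estimated at 100000 nM, with an expected range of 40000 nM to 200000 nM.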

Compound 4, half-maximal inhibitory concentration: > 100000 nM
Compound 4: only a limit was reported; the forecaster's own chance of this, stated with the estimate: 70%; the middle value lies on the limit itself.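

Compound 3 and compound 4 both give only a limit, so fluoro in place of methoxy on the aromatic carbon yields no readable step between them. The compounds shown leave open the size of this exchange and whether any change to the shared core would give a readable number, as the whole set stands at one point: the limit of > 100000 nM in this assay, at which 4 of the 4 values shown sit.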